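Replacing a Saturated Ring Amine by a Phenethyl Chain

The source may hold more compounds than are shown below. What is called first, only, known or untested is meant among the compounds shown, and "the series" means these compounds.

Measured compounds:
compound 1 `CCCCNc1nc(N)nc(C)c1CCCN1CCN(C)CC1` – 179 nM
compound 2 `CCCCNc1nc(N)nc(C)c1CCCN1CCCCCC1` – 178 nM

In an assay on HEK293 cells for agonist activity at Toll-like receptor 8 (Homo sapiens), read by spectrophotometry (on this read-out lower numbers stand for an effect already at smaller amounts and higher numbers for an effect only at larger amounts of compound), compound 1 gives 179 nM and compound 2 gives 178 nM. The step of a 1.0-fold lower number from compound 1 to compound 2 (0.00 log units; within the scatter) shows that exchanging one saturated ring amine for another at this place left the read-out unchanged, so compound 2 sits beside compound 1 and neither can be called the more potent.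

Compound 3 `CCCCNc1nc(N)nc(C)c1CCCCCc1ccccc1` carries the change (phenethyl in place of azepan-1-yl on a saturated chain carbon, three bonds along the chain from an aromatic carbon). Going by the values given here, only the step from compound 1 to compound 2 bears on this position, and it was flat; but it kept a ring amine in place, whereas here the hydrogen-bond acceptor leaves altogether and a phenethyl group enters. Among the compounds with values here, no measured step covers such a loss, so the outlook is uncertain. A modest step toward higher numbers is expected, a 2.2-fold higher number from compound 2 to compound 3 (0.35 log units; beyond the scatter), and compound 3 is estimated at 400 nM, within 150 nM to 1200 nM.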

Compound 3, half-maximal effective concentration: 830 nM
Compound 3: middle estimate off by 2.1-fold (0.32 log units), on the low side; the range from low to high includes it.
By their numbers in this assay, from the lowest: compounds 2 and 1 (each within the scatter of the next); then compound 3.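

In this assay, this position proves not to be indifferent to every change: the two saturated ring amines could not be told apart, yet phenethyl gives a 4.7-fold higher number from compound 2 to compound 3 (0.67 log units; beyond the scatter), and likewise a 4.6-fold higher number from compound 1 to compound 3 (0.67 log units; beyond the scatter). The place therefore accepts one ring amine for another, while a swap that removes the ring nitrogen and its hydrogen-bond acceptor and brings in an aromatic ring of carbon only moves the number upward beyond the scatter. No supporting measurement is available to show which part of this exchange matters. Still open, from the compounds shown here alone, is whether a pyridylethyl group, which keeps an aromatic ring but carries a ring nitrogen, would stay near compound 2 or near compound 3. An open-chain amine such as diethylamino at this place would test whether a ring is needed at all.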